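Series notes: 1,3-oxazol-4-yl for 1H-1,2,3-triazol-4-yl

The source may hold more compounds than are shown below. What is called first, only, known or untested is meant among the compounds shown, and "the series" means these compounds.

- compound 1 `O=C(c1cn[nH]c1)N1CCC(C(=O)N2N=CCC2c2ccccc2)CC1` at 360 ng.h/mL
- compound 2 `O=C(c1c[nH]nn1)N1CCC(C(=O)N2N=CCC2c2ccccc2)CC1` at 450 ng.h/mL

Going by the values given here, in an ADME assay on the whole organism (Rattus norvegicus) for pharmacokinetics, at a dose of 1 mg/kg by the intravenous route (on this read-out lower numbers stand for lower exposure and higher numbers for higher exposure at the dose given), compound 2 gives 450 ng.h/mL and sits within the scatter of the only other measured compound. Compound 3 `O=C(c1cocn1)N1CCC(C(=O)N2N=CCC2c2ccccc2)CC1` carries 1,3-oxazol-4-yl in place of 1H-1,2,3-triazol-4-yl on a carbonyl carbon, with 1,3-oxazol-4-yl in place of 1H-1,2,3-triazol-4-yl on a carbonyl carbon as the counted difference. Among the compounds with values here, the one measured step bearing on this is also an exchange of the group on that carbonyl carbon: a 1.3-fold higher number from compound 1 to compound 2 (0.10 log units; within the scatter) stays within the scatter. Within the data shown here, no measured compound carries 1,3-oxazol-4-yl, so the evidence is thin. No change beyond the scatter is expected, and the estimated 1.1-fold lower number from compound 2 to compound 3 (0.05 log units; within the scatter) is small. Compound 3 is estimated at 400 ng.h/mL with an expected range of 200 ng.h/mL to 800 ng.h/mL as the working figure.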

Compound 3, area under the concentration-time curve: 290 ng.h/mL
Compound 3: the middle estimate sits 1.4-fold (0.14 log units) above what was measured; measured number inside the range.
By their numbers in this assay, from the lowest: compounds 3, 1 and 2 (each within the scatter of the next).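

In this assay the position on the carbonyl carbon has now taken a third five-membered aromatic ring, and the new ring gives a 1.6-fold lower number from compound 2 to compound 3 (0.19 log units; within the scatter) and a 1.2-fold lower number from compound 1 to compound 3 (0.09 log units; within the scatter). The 1,3-oxazol-4-yl group has 0 hydrogen-bond donors and the 1H-1,2,3-triazol-4-yl group it replaces has 1 hydrogen-bond donor, so this difference in count comes with no step beyond the scatter on this read-out. No supporting measurement offers an explanation for this result.

Going by these compounds, whether a phenyl ring, a carboxylic acid or an open-chain amine on this carbonyl carbon would give a step beyond the scatter stays open. So does whether a change elsewhere on the shared core would move the number further than these exchanges of the ring.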